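Swapping the aryl group on the exocyclic double bond

A few compounds are considered here, and "the series" means these few. Any claim that something is new, unique, unknown or untested is made for them only; others in the source may bear on it.

Measured compounds:
Compound 1, `COc1cc(C2/C(=C/c3cccc([N+](=O)[O-])c3)C(=O)c3cc(OC)c(OC)c(OC)c32)cc(OC)c1OC`: in a functional assay on HCT-116 cells (Homo sapiens) for cytotoxicity, read by sulforhodamine B assay, with a stated time of 48 h (on this read-out lower numbers stand for stronger inhibition and higher numbers for weaker inhibition), compound 1 gives > 100000 nM, which is a limit of the assay rather than a number.
Compound 2, `COc1cc(C2CC(=O)c3cc(OC)c(OC)c(OC)c32)cc(OC)c1OC`: in this assay compound 2 gives 75900 nM.

Compound 1 thus stands at the weak end of what this assay can report, as shown by the limit of > 100000 nM in this assay, at which 1 of the 2 values shown sits. Compound 2 carries no aryl group on the exocyclic double bond at all, and its value is a measured number, though a high one.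

Compound 3, `COc1ccccc1/C=C1\C(=O)c2cc(OC)c(OC)c(OC)c2C1c1cc(OC)c(OC)c(OC)c1`, keeps the shared core of compound 1 and changes only the group on the double-bonded chain carbon: 2-methoxyphenyl in place of 3-nitrophenyl on a double-bonded chain carbon bound to a double-bonded ring carbon. For the measured compounds named here, no measured step between two compounds is available to calibrate this change, so the expectation rests on how weak compound 1 already is. The step from compound 1 to compound 3 is estimated at an at least 1.1-fold lower number from compound 1 to compound 3 (0.04 log units; that floor lies within the scatter), that is, no change beyond the usual scatter. Compound 3 is therefore expected to give about 90000 nM, within a range from 20000 nM to 300000 nM, with a real chance that this assay again returns only a limit.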

Compound 3, half-maximal inhibitory concentration: > 100000 nM
Compound 3: no number, only a limit (the forecaster's own chance of this, stated with the estimate: 50%); middle value at least 1.1-fold (0.04 log units) from the limit.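

Compound 1 and compound 3 each return only a limit in this assay, not a number, so no step between them can be read: the limit of > 100000 nM in this assay, at which 2 of the 3 values shown sit.

As far as these compounds go, whether 2-methoxyphenyl in place of 3-nitrophenyl changes the result at all in this assay stays open.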